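The source may report more compounds than this note shows. Statements on the series, on what has been measured and on what is new or still open speak of the compounds shown alone.

Measured in a functional assay on A549 cells (Homo sapiens) for inhibition, read by MTT assay, with a stated time of 24 h; a higher number here means a weaker inhibitor, a lower number a stronger inhibitor:
Compound 1 `FC(F)(F)c1ccc(/C=C/[C@@H]2CCCCN2)cc1`: 2.82 ug/mL
Compound 2 `Cc1cccc(C)c1/C=C/[C@@H]1CCCCN1`: 7.28 ug/mL

Compound 1 has the lower number of the pair, and the gap to compound 2 lies beyond the usual scatter. Compound 3 `CC(=O)c1ccc(/C=C/[C@@H]2CCCCN2)cc1` has acetyl in place of trifluoromethyl on an aromatic carbon of the core of compound 1 (acetyl in place of trifluoromethyl on an aromatic carbon). Going by the values given here, no measured pair shows this exchange, so the only guide in this assay is the spread from compound 1 at 2.82 ug/mL to compound 2 at 7.28 ug/mL. A moderate rise in the number is expected, a 1.8-fold higher number from compound 1 to compound 3 (0.25 log units; within the scatter). For compound 3 the estimated value is 5 ug/mL, with an expected range from 2.2 ug/mL to 12 ug/mL.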

Compound 3, half-maximal inhibitory concentration: 3.69 ug/mL
Compound 3: the middle estimate sits 1.4-fold (0.13 log units) above what was measured; the range from low to high includes it.
By their numbers in this assay, from the lowest: compounds 1, 3 and 2 (each within the scatter of the next, the first and the last beyond it).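

In this assay, going by these compounds alone, the exchange of trifluoromethyl for acetyl on an aromatic carbon gives a 1.3-fold higher number from compound 1 to compound 3 (0.12 log units; within the scatter) as the first direct reading at this position. The two groups cannot be told apart here, although acetyl brings one hydrogen-bond acceptor and trifluoromethyl none. Nothing measured alongside these values accounts for this result. Going by these compounds, whether an amine, a carboxylic acid or a longer chain at this position would also stay within the scatter of compound 1 remains open. Also open, on these data alone, is how other ring carbons respond to a single group, since compound 2 differs from compound 1 in more than one place.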